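This account rests on a few compounds, and the source may have more. Where it says the series, first, only, none or still open, it means among the compounds named here.

In a functional assay on MCF7 cells (Homo sapiens) for cytotoxicity, read by MTT assay, with a stated time of 96 h (on this read-out higher numbers stand for weaker inhibition and lower numbers for stronger inhibition), two compounds have been measured:

Compound 1 `COc1cc(C(=O)c2cn(-c3ccccc3)cc2-c2cccc([N+](=O)[O-])c2)cc(OC)c1OC`: 50 nM
Compound 2 `COc1cc(C(=O)c2cn(-c3cccc(C)c3)cc2-c2ccccc2Cl)cc(OC)c1OC`: 420 nM

Compound 2 has the higher number of the two, meaning weaker inhibition, and the gap to compound 1 lies beyond the scatter. Compound 3 `COc1cc(C(=O)c2cn(-c3cccc(C)c3)cc2-c2cccc([N+](=O)[O-])c2)cc(OC)c1OC` differs from compound 2 in one place, with 3-nitrophenyl in place of 2-chlorophenyl on an aromatic carbon. Going by the values given here, no measured pair shows this change alone. Compound 1 also carries 3-nitrophenyl and gives 50 nM, so a drop beyond the scatter is expected in this assay. The expected change is a 7.0-fold lower number from compound 2 to compound 3 (0.85 log units; beyond the scatter). The estimated value for compound 3 is 60 nM, within an expected range of 20 nM to 200 nM.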

Compound 3, half-maximal inhibitory concentration: 880 nM
For compound 3 the middle estimate is 15-fold (1.17 log units) below the measured one; the measured number lies above the stated range.
By their numbers in this assay, from the lowest: compound 1; then compound 2; then compound 3.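

In this assay, 3-nitrophenyl in place of 2-chlorophenyl on this carbon of the five-membered ring brings no gain when the 3-methylphenyl group is present, giving a 2.1-fold higher number from compound 2 to compound 3 (0.32 log units; beyond the scatter). The methyl group matters more: methyl in place of hydrogen on that phenyl group gives an 18-fold higher number from compound 1 to compound 3 (1.25 log units; beyond the scatter), so 3-nitrophenyl alone does not secure a low number. Going by these compounds, it remains open whether an amine or a nitrile in place of the nitro group would behave the same way, or whether a methoxy group in place of the methyl would cost as much. Nothing at hand gives a cause for either step.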